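The source may report more compounds than this note shows. Statements on the series, on what has been measured and on what is new or still open speak of the compounds shown alone.

Series notes. Compound 3 `c1ccc2c(c1)CN[C@@H](CN(CC[C@@H]1CCCNC1)[C@H]1CCCc3cccnc31)C2` gives 23% in an ADME assay on microsomes from liver (Mus musculus) for metabolic stability, read by LC-MS, with a stated time of 10 min, tested at 0.5 uM (a lower number here means that less of the compound is left, a higher number that more of the compound is left), the lowest of the three numbers to hand. Compound 1 `c1ccc2c(c1)CN[C@@H](CN(CCC1CCNCC1)[C@H]1CCCc3cccnc31)C2` gives 32% in this assay, and the gap is a number 9 percentage points lower from compound 1 to compound 3 (within the scatter). Compound 2 `c1ccc2c(c1)CN[C@@H](CN(CCCN1CCNCC1)[C@H]1CCCc3cccnc31)C2` gives 92% in this assay, and a number 69 percentage points lower from compound 2 to compound 3 (beyond the scatter) leaves compound 3 furthest from it.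

Compound 4 `NC(=O)N1CCN(CCCN(C[C@H]2Cc3ccccc3CN2)[C@H]2CCCc3cccnc32)CC1` awaits measurement. Its change from compound 3 is (4-carbamoylpiperazin-1-yl)methyl in place of piperidin-3-yl on a saturated chain carbon, two bonds along the chain from an amine nitrogen. Within the data shown here, two measured steps bear on this. The first is a number 60 percentage points higher from compound 1 to compound 2 (beyond the scatter). The second, in the opposite sense, is a number 69 percentage points lower from compound 2 to compound 3 (beyond the scatter). Both exchange a piperidinyl group for (piperazin-1-yl)methyl at the same place, and both are large. Among the measured compounds shown here, compound 4 carries (4-carbamoylpiperazin-1-yl)methyl rather than the plain (piperazin-1-yl)methyl of compound 2, so the carbamoyl part itself has no measured step in this set. Even so, the expected step in this assay is a large rise, a number 57 percentage points higher from compound 3 to compound 4 (beyond the scatter). Compound 4 is therefore estimated at 80%, with a range from 55% to 98%.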

Compound 4, percent of the compound remaining: 42%
Estimate against measurement, compound 4: 38 percentage points above; the whole stated range lies above it.
By their numbers in this assay, from the lowest: compounds 3, 1 and 4 (each within the scatter of the next, the first and the last beyond it); then compound 2.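

In this assay, the amine nitrogen in the ring of compound 2 proves sensitive to substitution: carbamoyl in place of hydrogen there gives a number 50 percentage points lower from compound 2 to compound 4 (beyond the scatter). The (4-carbamoylpiperazin-1-yl)methyl group keeps only part of the gain seen with the plain (piperazin-1-yl)methyl group, with a number 19 percentage points higher from compound 3 to compound 4 (beyond the scatter), and against piperidin-4-yl the comparison gives a number 10 percentage points higher from compound 1 to compound 4 (within the scatter). No measurement to hand accounts for the loss that comes with carbamoyl.

On these data alone, it remains open whether this loss is specific to carbamoyl or follows any group on that ring nitrogen, such as methyl or acetyl. As far as these compounds go, it also remains open whether a shorter or longer chain to the piperazine ring would change the size of the carbamoyl step.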